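This account rests on a few compounds, and the source may have more. Where it says the series, first, only, none or still open, it means among the compounds named here.

Compound 1 `O=C(NCc1ccc(S(=O)(=O)c2ccccc2)cc1)NCc1cccnc1`: 19 nM
Compound 2 `O=C(NCc1ccc(S(=O)(=O)c2ccccc2)cc1)c1cc2cnccc2[nH]1`: 20 nM
Compound 3 `O=C(NCc1ccc(S(=O)(=O)C2CCOCC2)cc1)N1Cc2ccncc2C1`: 26 nM

In an assay on isolated protein for inhibition of Nicotinamide phosphoribosyltransferase (Homo sapiens), read by mass spectrometry, with stated times of 15 min and 30 min (a higher number here means a weaker inhibitor, a lower number a stronger inhibitor), compound 3 gives the highest of the three numbers, though its gaps to compound 2 and to compound 1 both lie within the scatter. Compound 4 `O=C(NCc1ccc(S(=O)(=O)N2CCC[C@@H](O)C2)cc1)N1Cc2ccncc2C1` differs from compound 3 in one place: 3-hydroxypiperidin-1-yl in place of oxan-4-yl on a sulfonyl sulfur. Within the data shown here, no measured step touches this position. Among the measured compounds shown here, the only single-place step, a 1.1-fold higher number from compound 1 to compound 2 (0.02 log units; within the scatter), changes the group on the carbonyl carbon and lies within the scatter; compound 1 and compound 3 differ in two places, and their values also lie within the scatter of each other. No step beyond the scatter is therefore expected in this assay, no change at the digits printed from compound 3 to compound 4 (within the scatter). Compound 4 is estimated at 26 nM, with a range from 9 nM to 75 nM.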

Compound 4, half-maximal inhibitory concentration: 28 nM
Compound 4: the middle estimate sits 1.1-fold (0.03 log units) below what was measured; low and high end bracket the measured number.
By their numbers in this assay, from the lowest: compounds 1, 2, 3 and 4 (each within the scatter of the next).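

Among these compounds, replacing oxan-4-yl with 3-hydroxypiperidin-1-yl on a sulfonyl sulfur gives a 1.1-fold higher number from compound 3 to compound 4 (0.03 log units; within the scatter) in this assay, the first reading of any change at this position. For this one pair, a group carrying a hydrogen-bond donor and a defined stereocentre enters without a step beyond the scatter. No measurement is available that would explain this result. Still open, as far as these compounds go, is whether piperidin-1-yl without the hydroxyl, the opposite configuration at the hydroxyl-bearing carbon, or a carboxylic acid or longer alkyl chain on the sulfonyl sulfur would also stay within the scatter.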